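This account rests on a few compounds, and the source may have more. Where it says the series, first, only, none or still open, it means among the compounds named here.

Compound 3 `CCn1cc(C(=O)N2N=C(c3cc4ccccc4o3)CC2c2cccc([N+](=O)[O-])c2)c(=O)c2ccc(C)nc21` stands at a limit rather than a number in an ADME assay on Vero cells (Chlorocebus sabaeus) for cytotoxicity, read by MTT assay, with a stated time of 72 h (a lower number here means a stronger inhibitor, a higher number a weaker inhibitor), giving > 164000 nM. Compound 1 `O=C(c1ccncc1)N1N=C(c2cc3ccccc3o2)CC1c1cccc([N+](=O)[O-])c1` also reaches only a limit in this assay, > 240000 nM. Compound 2 `O=C(c1ccncc1)N1N=C(c2cc3ccccc3o2)CC1c1ccccc1` likewise gives a limit, > 209000 nM. The step that the two limits leave unreadable from compound 1 to compound 2 stays unreadable because the limit of > 209000 nM in this assay, at which 1 of the 3 values shown sits, and the limit of > 240000 nM in this assay, at which 1 of the 3 values shown sits, are both limits. Compound 4 `CCn1cc(C(=O)N2N=C(c3cc4ccccc4o3)CC2c2ccco2)c(=O)c2ccc(C)nc21` differs from compound 3 by furan-2-yl in place of 3-nitrophenyl on a saturated ring carbon. Going by the values given here, no measured step gives a readable size for this kind of change, so no step beyond the scatter is expected, and compound 4 is estimated to remain at a limit, around 200000 nM with a range from 100000 nM to 400000 nM, meaning an expected step that the limit leaves unreadable from compound 3 to compound 4.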

Compound 4, half-maximal inhibitory concentration: > 185000 nM
Compound 4 ended at the assay's limit (the forecaster's own chance of this, stated with the estimate: 85%); the middle value is on the limit's open side.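

Compound 3 and compound 4 both stand at limits in this assay, and the step between them cannot be read. The compounds shown leave open what size of step, if any, these changes on the shared core produce.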